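The source may hold more compounds than are shown below. What is called first, only, known or untested is meant among the compounds shown, and "the series" means these compounds.

Measured compounds:
- compound 1, `COc1ccc(-c2cc3ccc(OCCCCCn4cc(CNC(=O)CCCCC5CCSS5)nn4)cc3oc2=O)cc1`, gives 34.5% in a functional assay on PC-12 cells (Rattus norvegicus) for cytotoxicity, read by MTT assay, with stated times of 3 h and 2 h, tested at 0.1 uM; on this read-out lower numbers stand for a weaker effect and higher numbers for a stronger effect at the one concentration tested
- compound 2, `COc1ccc(-c2cc3ccc(OCCCCCn4cc(CNC(=O)CCCCC5CCSS5)nn4)cc3oc2=O)cc1OC`, gives 38.5% in this assay
- compound 3, `O=C(CCCCC1CCSS1)NCc1cn(CCCCCOc2ccc3cc(-c4ccc(Br)cc4)c(=O)oc3c2)nn1`, gives 41.8% in this assay

All three share one core and differ only in the aryl group attached to it. Compound 3 has the highest of the three numbers, but its lead is small: the step of a number 3.3 percentage points higher from compound 2 to compound 3 (within the scatter) and the step of a number 7.3 percentage points higher from compound 1 to compound 3 (within the scatter) both lie within the scatter, as does the step of a number 4 percentage points higher from compound 1 to compound 2 (within the scatter). On these numbers the three compounds cannot be told apart.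

Compound 4, `O=C(CCCCC1CCSS1)NCc1cn(CCCCCOc2ccc3cc(-c4ccc(Cl)c(Cl)c4)c(=O)oc3c2)nn1`, has not yet been measured. It differs from compound 3 by 3,4-dichlorophenyl in place of 4-bromophenyl on an aromatic carbon. The measured steps that bear on this are the ones that also swap the aryl group: the step from compound 1 to compound 3 and the step from compound 2 to compound 3, both within the scatter. A change of the same kind is therefore expected to give no step beyond the scatter in this assay.

Compound 4 is expected to give 42%, within the range 32% to 52%, an estimated step of a number 0.2 percentage points higher from compound 3 to compound 4 (within the scatter).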

Compound 4, a percentage reported as activity, at one concentration (the size of the read-out at that concentration, not a potency): 39.7%
For compound 4 the middle estimate is 2.3 percentage points above the measured one; low and high end bracket the measured number.
By their numbers in this assay, from the lowest: compounds 1, 2, 4 and 3 (each within the scatter of the next).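

In this assay the change to two chlorines on the phenyl ring, in place of one bromine, gives a number 2.1 percentage points lower from compound 3 to compound 4 (within the scatter) and so adds a further halogen pattern at this position without moving the number beyond the scatter. Set against the two methoxy-bearing aryl groups, the 3,4-dichlorophenyl group gives a number 1.2 percentage points higher from compound 2 to compound 4 (within the scatter) and a number 5.2 percentage points higher from compound 1 to compound 4 (within the scatter) in the same read-out, which means that four aryl groups with methoxy, bromo or chloro substituents now lie within the scatter of one another at this aromatic carbon. No measurement is available that could explain why these different groups give such similar numbers.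

On these data alone, all four groups are phenyl rings carrying methoxy, bromo or chloro substituents, so it remains open whether an amine or a carboxylic acid on that ring would produce a step beyond the scatter. Also open, as far as these compounds go, is whether the compounds would separate at other concentrations, or whether a longer chain between the shared core and the triazole-bearing end of the molecule would change the picture.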